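The source may hold more compounds than are shown below. What is called first, only, known or untested is meant among the compounds shown, and "the series" means these compounds.

Compound 1 `COc1cccc(N2CCN(CCCCN3C(=O)SC4(CCCC4)C3=O)CC2)n1`: in a functional assay on the whole organism for inhibition, with Rattus norvegicus as the target (a lower number here means that less compound is needed, a higher number that more compound is needed for the effect), compound 1 gives > 100 mg/kg, which is a limit of the assay rather than a number.
Compound 2 `COc1cccc(N2CCN(CCCCN3C(=O)CC(C)(C)CC3=O)CC2)n1`: in this assay compound 2 gives 76.2 mg/kg.
Compound 3 `COc1cccnc1N1CCN(CCCCN2C(=O)SC3(CCCC3)C2=O)CC1`: in this assay compound 3 gives < 57 mg/kg, again a limit of the assay and not a number.

Going by these compounds, compound 3 thus stands only at a limit, and where its true dose lies under that limit is unknown. Among the measured compounds shown here, the one measured step, an at least 1.7-fold lower number from compound 1 to compound 3 (0.24 log units; that floor lies within the scatter), runs between two limits, the limit of > 100 mg/kg in this assay, at which 1 of the 3 values shown sits, and (the limit of < 57 mg/kg in this assay, at which 1 of the 3 values shown sits), so its floor lies within the scatter and its real size is open.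

Compound 4 `N#Cc1cccnc1N1CCN(CCCCN2C(=O)SC3(CCCC3)C2=O)CC1` differs from compound 3 by cyano in place of methoxy on an aromatic carbon. For the measured compounds named here, no measured step touches this change; the only step measured moved the methoxy around the pyridine ring and left both limits in place. There is therefore no ground for expecting a step beyond the scatter from compound 3 to compound 4, and the expected step, a step that the limit leaves unreadable from compound 3 to compound 4, is set at about none, with wide uncertainty because compound 3 itself rests on < 57 mg/kg.

Compound 4 is expected to give 40 mg/kg in this assay, with a range from 15 mg/kg to 100 mg/kg.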

Compound 4, dose for half-maximal effect: 29.3 mg/kg
The estimate for compound 4 lay 1.4-fold (0.14 log units) above the measured number; the range from low to high includes it.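

In this assay compound 4 gives 29.3 mg/kg, a real number rather than a limit, and so the first readable dose among the compounds shown that share the core of compound 1. Among the compounds shown here, with 3-cyanopyridin-2-yl in place of 6-methoxypyridin-2-yl on the ring amine nitrogen, the result is an at least 3.4-fold lower number from compound 1 to compound 4 (0.53 log units; beyond the scatter), the first step here that clears the usual scatter of the measurement, showing that this part of the molecule can change the dose needed in a way that can be read. The step to cyano from the 3-methoxy group cannot be read, because compound 3 has no number, only a limit: the limit of < 57 mg/kg in this assay, at which 1 of the 4 values shown sits.

Going by these compounds, whether cyano at this place truly needs less compound than methoxy stays open, as does what other groups on this aromatic carbon, such as a chlorine atom, an amine or a carboxylic acid, would do to the dose. Also open, on these data alone, is whether the 3-cyanopyridin-2-yl group would give a similar result on the core of compound 2, which carries the 6-methoxypyridin-2-yl group.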